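This account rests on a few compounds, and the source may have more. Where it says the series, first, only, none or still open, it means among the compounds named here.

Measured so far in a functional assay on PC-3 cells (Homo sapiens) for inhibition, read by sulforhodamine B assay, with a stated time of 48 h; a higher number here means a weaker inhibitor of growth, a lower number a stronger inhibitor of growth:
compound 1 `CC1(/C=C/c2ccccc2)C=CC(=O)O1`: 86900 nM
compound 2 `CC1(/C=C/c2ccccc2C(F)(F)F)C=CC(=O)O1`: 17900 nM
compound 3 `COc1ccc(/C=C/C2(C)C=CC(=O)O2)c(OC)c1`: 63500 nM

Compound 3, at 63500 nM, lies within the scatter of compound 1, at 86900 nM. Compound 2, at 17900 nM, has a lower number than compound 3, and the gap is beyond the scatter. The next compound is compound 4 `COc1ccc(/C=C/C2(C)C=CC(=O)O2)c(OC)c1OC`, which differs from compound 3 by methoxy in place of hydrogen on an aromatic carbon.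

For the measured compounds named here, no measured step adds methoxy on its own. Going by the values given here, the only single-place step, a 4.9-fold lower number from compound 1 to compound 2 (0.69 log units; beyond the scatter), is modest and brings in trifluoromethyl, so it bears only loosely on this change. Closer evidence comes from the values: compound 3 carries two methoxy groups, yet its 63500 nM stays within the scatter of compound 1. A third methoxy group is therefore expected to move this assay little, with no shift beyond the scatter in either direction. The expected step is a 1.1-fold lower number from compound 3 to compound 4 (0.02 log units; within the scatter). Compound 4 is estimated at 60000 nM, with an expected range of 30000 nM to 110000 nM.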

Compound 4, concentration for total growth inhibition: 90000 nM
Estimate against measurement, compound 4: 1.5-fold (0.18 log units) below; low and high end bracket the measured number.
By their numbers in this assay, from the lowest: compound 2; then compounds 3, 1 and 4 (each within the scatter of the next).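

In this assay, methoxy on the aromatic carbon ortho to two methoxy groups gives a 1.4-fold higher number from compound 3 to compound 4 (0.15 log units; within the scatter), so compound 3 and compound 4 cannot be told apart at this position. For the compounds shown here, this is the first single-place reading for methoxy, and it stays within the scatter, whereas the trifluoromethyl change gives a 4.9-fold lower number from compound 1 to compound 2 (0.69 log units; beyond the scatter), a step at a different place on the aromatic ring that lies beyond it. No measurement shown here accounts for the size of the methoxy step.

Open, from the compounds shown here alone, is whether a group other than methoxy at this position, such as an amine or a carboxylic acid, would leave the number as little moved. Going by these compounds alone, also open is what each of the two methoxy groups of compound 3 contributes alone, since no single-place step isolates either one.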